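A few compounds are considered here, and "the series" means these few. Any claim that something is new, unique, unknown or untested is made for them only; others in the source may bear on it.

Compound 1 `Cc1cc(-c2ccccc2)n(/C(N)=N/S(=O)(=O)c2cc(C)c(Cl)cc2SCc2ccccc2C)n1`: 42000 nM
Compound 2 `Cc1cc(-c2ccccc2)n(/C(N)=N/S(=O)(=O)c2cc(C)c(Cl)cc2SCc2ccccc2Cl)n1`: 170000 nM
Compound 3 `Cc1cccc(CSc2cc(Cl)c(C)cc2S(=O)(=O)/N=C(\N)n2nc(C)cc2-c2ccccc2)c1`: 34000 nM

In a functional assay on HCT-116 cells (Homo sapiens) for cytotoxicity, read by MTT assay, with a stated time of 72 h (on this read-out lower numbers stand for stronger inhibition and higher numbers for weaker inhibition), compound 3 gives the lowest of the three numbers. Compound 1 stands nearest to it, since a 1.2-fold lower number from compound 1 to compound 3 (0.09 log units; within the scatter); compound 2 stands furthest, since a 5.0-fold lower number from compound 2 to compound 3 (0.70 log units; beyond the scatter). Compound 4 `Cc1cc(-c2ccccc2)n(/C(N)=N/S(=O)(=O)c2cc(C)c(Cl)cc2SCc2ccccc2)n1` differs from compound 3 in one place: hydrogen in place of methyl on an aromatic carbon. Within the data shown here, no measured step removes a group from that ring outright. Among the measured compounds shown here, the steps that bear on it are the two that exchange the group on the benzyl ring, a 1.2-fold lower number from compound 1 to compound 3 (0.09 log units; within the scatter) and a 5.0-fold lower number from compound 2 to compound 3 (0.70 log units; beyond the scatter), together with a 4.0-fold higher number from compound 1 to compound 2 (0.61 log units; beyond the scatter) on the other ring. Shifting the methyl from one position of the benzyl ring to another hardly moved the number, while putting chloro in place of methyl raised it modestly. Taking the methyl away entirely is therefore expected to shift the number only a little, if at all, most likely toward a somewhat higher value. Compound 4 is estimated at 45000 nM, between 20000 nM and 100000 nM, which means an expected 1.3-fold higher number from compound 3 to compound 4 (0.12 log units; within the scatter).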

Compound 4, half-maximal inhibitory concentration: 10000 nM
For compound 4 the middle estimate is 4.5-fold (0.65 log units) above the measured one; the whole stated range lies above it.
By their numbers in this assay, from the lowest: compound 4; then compounds 3 and 1 (each within the scatter of the next); then compound 2.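

In this assay, compound 4, which carries a plain benzyl group, shows that this ring is not indifferent to substitution: removing the group lowers the number each time, with a 3.4-fold lower number from compound 3 to compound 4 (0.53 log units; beyond the scatter) for the methyl of the 3-methylbenzyl group, a 4.2-fold lower number from compound 1 to compound 4 (0.62 log units; beyond the scatter) for the methyl of the 2-methylphenyl group and a 17-fold lower number from compound 2 to compound 4 (1.23 log units; beyond the scatter) for the chloro of the 2-chlorophenyl group. The earlier compounds showed only that moving the methyl changed little, whereas the unsubstituted ring now stands apart from all three substituted ones, and no compound shown goes against this. No supporting data are available to explain the difference. The compounds shown leave open whether a fluoro, a methoxy or an amine on this ring would also raise the number. They also leave open whether any group there could bring it below that of compound 4.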